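The source may report more compounds than this note shows. Statements on the series, on what has been measured and on what is new or still open speak of the compounds shown alone.

In a functional assay on SH-SY5Y cells (Homo sapiens) for cytotoxicity, read by MTT assay, with a stated time of 72 h (a lower number here means a stronger inhibitor, a higher number a weaker inhibitor), three compounds carry a value so far:

compound 1, `O=C1c2c[n+]([O-])c3ccccc3c2C(=O)c2c1c1ccccc1n2Cc1cn(C[C@@H](O)CO)nn1`: > 500 nM, which is a limit of the assay and not a number
compound 2, `O=C1c2c[n+]([O-])c3ccccc3c2C(=O)c2c1c1ccccc1n2CCCCN1CCCCC1`: 230 nM
compound 3, `O=C1c2c[n+]([O-])c3ccccc3c2C(=O)c2c1c1ccccc1n2CCCCN1CCNCC1`: 1240 nM

Compound 3 stands at the highest of the two numbers; its nearest neighbour is compound 2, separated by a 5.4-fold higher number from compound 2 to compound 3 (0.73 log units; beyond the scatter), a step beyond the usual scatter. Compound 1 sits only at the limit of > 500 nM in this assay, at which 1 of the 3 values shown sits, so its distance to compound 3 cannot be read.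

Compound 4, `CN(C)CCCCn1c2c(c3ccccc31)C(=O)c1c[n+]([O-])c3ccccc3c1C2=O`, differs from compound 3 by dimethylamino in place of piperazin-1-yl on a saturated chain carbon, four bonds along the chain from an aromatic nitrogen. Among the compounds with values here, the one measured step at this same place is a 5.4-fold higher number from compound 2 to compound 3 (0.73 log units; beyond the scatter), where piperazin-1-yl replaced piperidin-1-yl and the number rose. The change to compound 4 again swaps the amine at that position, this time for dimethylamino, a group that, like piperidin-1-yl, lacks the second ring nitrogen. The expectation is therefore a return toward the number of compound 2, as a 3.5-fold lower number from compound 3 to compound 4 (0.55 log units; beyond the scatter). Compound 4 is thus expected to give about 350 nM, within a range from 150 nM to 900 nM.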

Compound 4, half-maximal inhibitory concentration: 250 nM
The estimate for compound 4 lay 1.4-fold (0.15 log units) above the measured number; the measured number falls inside the stated range.
By their numbers in this assay, from the lowest: compounds 2 and 4 (each within the scatter of the next); then compound 3.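

In this assay, the swap of piperazin-1-yl for dimethylamino gives a 5.0-fold lower number from compound 3 to compound 4 (0.70 log units; beyond the scatter), so the high number of compound 3 now stands out against a second amine and not only against piperidin-1-yl. A ring at the chain end is also not needed to reach the lower numbers, as the open-chain dimethylamino and the ring of piperidin-1-yl cannot be told apart in a 1.1-fold higher number from compound 2 to compound 4 (0.04 log units; within the scatter). Compound 1 carries a limit and not a number, so an at least 2.0-fold lower number from compound 1 to compound 4 (0.30 log units; that floor lies within the scatter) offers only a floor: the limit of > 500 nM in this assay, at which 1 of the 4 values shown sits.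

Going by these compounds, it remains open whether the second ring nitrogen of piperazin-1-yl is what goes with the higher number, which morpholin-4-yl or 4-methylpiperazin-1-yl at the same place could help to separate. The compounds shown also leave open how these amines behave on a shorter or longer chain.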